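Two diarylpyrimidine analogues and a chloro-to-methoxy swap

This account rests on a few compounds, and the source may have more. Where it says the series, first, only, none or still open, it means among the compounds named here.

Two measured compounds share the same core. Compound 1 `Cc1cc(Oc2cc(N)nc(Nc3ccc(C#N)cc3)n2)ccc1-c1ccc(C#N)cc1` gives 34300 nM in a toxicity assay on MT4 cells (Homo sapiens) for cytotoxicity, read by MTT assay; on this read-out higher numbers stand for lower toxicity in this test and lower numbers for higher toxicity in this test. Compound 2 `Cc1cc(-c2cccc(Cl)c2)cc(C)c1Oc1cc(N)nc(Nc2ccc(C#N)cc2)n1` gives 22300 nM in this assay, the lower of the two numbers on record, though its gap to compound 1 lies within the scatter of repeated measurements, so no order between the two can be read from these values.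

Compound 3 `COc1cccc(-c2cc(C)c(Oc3cc(N)nc(Nc4ccc(C#N)cc4)n3)c(C)c2)c1` differs from compound 2 in one place: methoxy in place of chloro on an aromatic carbon. Cut one bond further out, the change reads 3-chlorophenyl to 3-methoxyphenyl. For the measured compounds named here, no measured pair in the set carries this same change, so there is no step to lean on. Across the two measured compounds, varying the outer aryl group left the cytotoxic concentration within scatter, and the present change is expected to do the same, with the step from compound 2 to compound 3 estimated at a 1.3-fold higher number from compound 2 to compound 3 (0.10 log units; within the scatter). For compound 3 the expected value in this assay is 28000 nM, with a range from 10000 nM to 80000 nM.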

Compound 3, half-maximal cytotoxic concentration: 19300 nM
The estimate for compound 3 lay 1.5-fold (0.16 log units) above the measured number, within the range that was stated.
By their numbers in this assay, from the lowest: compounds 3, 2 and 1 (each within the scatter of the next).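

Methoxy in place of chloro gives the first one-place comparison in the series, and in this assay the step is a 1.2-fold lower number from compound 2 to compound 3 (0.06 log units; within the scatter) and lies within the scatter. On this aromatic carbon, meta to a large group, chloro with 1 heavy atom and 0 hydrogen-bond acceptors gives way to methoxy with 2 heavy atoms and 1 hydrogen-bond acceptor, yet the two compounds cannot be told apart on this read-out. This rests on a single pair, and no available data bear on the reason for the result.

Going by these compounds, whether an amine, a carboxylic acid or a longer alkoxy chain on the same carbon would also stay within the scatter remains open. Also open, on these data alone, is whether the same swap would read alike with other substituents on the shared core.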